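From compound 2 to its 4-fluorophenyl analogue

This account rests on a few compounds, and the source may have more. Where it says the series, first, only, none or still open, it means among the compounds named here.

In a functional assay on RL cells (Homo sapiens) for cytotoxicity, with a stated time of 48 h (a lower number here means a stronger inhibitor, a higher number a weaker inhibitor), compound 1 (`COc1cccc(/C=C/C(=O)c2c(OC)cc(OC)cc2OC)c1`) gives 5900 nM and compound 2 (`COc1cc(OC)c(C(=O)/C=C/c2ccccc2)c(OC)c1`) gives 6900 nM and so stands within the scatter of compound 1. Compound 3 (`COc1cc(OC)c(C(=O)/C=C/c2ccc(F)cc2)c(OC)c1`) differs from compound 2 in one place: fluoro in place of hydrogen on an aromatic carbon. Among the measured compounds shown here, the one measured step that bears on this, hydrogen in place of methoxy on an aromatic carbon, is a 1.2-fold higher number from compound 1 to compound 2 (0.07 log units; within the scatter) (within the scatter). In this assay no step beyond the scatter is therefore expected. The estimated step is a 1.2-fold lower number from compound 2 to compound 3 (0.06 log units; within the scatter) (an expectation only). Compound 3 is expected at 6000 nM (estimated range 2500 nM to 14000 nM).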

Compound 3, half-maximal inhibitory concentration: 6400 nM
Estimate against measurement, compound 3: 1.1-fold (0.03 log units) below; low and high end bracket the measured number.
By their numbers in this assay, from the lowest: compounds 1, 3 and 2 (each within the scatter of the next).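

In this assay, replacing phenyl with 4-fluorophenyl gives a 1.1-fold lower number from compound 2 to compound 3 (0.03 log units; within the scatter) and so shows that fluoro, on this aromatic carbon para to a large group, brings no change beyond the scatter. Exchanging 3-methoxyphenyl for 4-fluorophenyl gives a 1.1-fold higher number from compound 1 to compound 3 (0.04 log units; within the scatter) and thus leaves these three compounds undivided by this assay. No evidence at hand explains this result. From the compounds shown here alone, it remains open whether an amine or a carboxylic acid on this same aromatic carbon would move the number beyond the scatter.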